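A few compounds are considered here, and "the series" means these few. Any claim that something is new, unique, unknown or untested is made for them only; others in the source may bear on it.

- Compound 1 `COc1ccccc1C(=O)n1c(-c2cn(C)c3ccc(Br)cc23)nc2ccccc21`: 12800 nM
- Compound 2 `COc1ccc(C(=O)n2c(-c3cn(C)c4ccc(Br)cc34)nc3ccccc32)cc1`: 11300 nM

In a functional assay on A549 cells (Homo sapiens) for inhibition, read by MTT assay, with a stated time of 24 h (a lower number here means a stronger inhibitor of growth, a higher number a weaker inhibitor of growth), compound 2 at 11300 nM lies within the scatter of compound 1 at 12800 nM, so the two cannot be told apart. Compound 3 `COc1ccc(C(=O)n2c(-c3cn(C)c4ccc(Br)cc34)nc3ccccc32)cc1OC` has methoxy in place of hydrogen on an aromatic carbon of compound 2, turning 4-methoxyphenyl into 3,4-dimethoxyphenyl: methoxy in place of hydrogen on an aromatic carbon. Among the measured compounds shown here, the one measured step, a 1.1-fold lower number from compound 1 to compound 2 (0.05 log units; within the scatter), exchanges 2-methoxyphenyl for 4-methoxyphenyl and stays within the scatter, though it adds no group. On that slender evidence, the expected step, a 1.1-fold lower number from compound 2 to compound 3 (0.03 log units; within the scatter), is not expected to go beyond the scatter. Compound 3 is estimated at 10500 nM, with an expected range of 4500 nM to 24000 nM.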

Compound 3, concentration for 50% growth inhibition: 3400 nM
Compound 3: middle estimate off by 3.1-fold (0.49 log units), on the high side, outside the stated range (below it).
By their numbers in this assay, from the lowest: compound 3; then compounds 2 and 1 (each within the scatter of the next).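

In this assay, among the compounds shown here, methoxy ortho to the existing methoxy group gives a 3.3-fold lower number from compound 2 to compound 3 (0.52 log units; beyond the scatter) and is the first step to go beyond the scatter. Taking 3,4-dimethoxyphenyl in place of 2-methoxyphenyl gives a 3.8-fold lower number from compound 1 to compound 3 (0.58 log units; beyond the scatter) as well, so among these compounds the clear drop appears only with a second methoxy group, not with 4-methoxyphenyl alone. Nothing available accounts for this difference. The compounds shown leave open whether a hydroxy group, an amine or a longer alkoxy chain at this place would give a similar number, and whether the second methoxy group would count for as much elsewhere on the same ring.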